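Nitro for Allyl on a Guinea-Pig Lung Series

The compounds below may be only part of what the source reports. "The series", "measured", "known", "first", "only" and "open" are said of these compounds alone.

Compound 1, `C=CCc1cc(C(=O)N[C@H](C)CCCc2cccnc2)ccc1-c1ccc(OC)c(OC)c1`, gives 0.33 mg/kg in a functional assay on the whole organism (lung) for inhibition, with Cavia porcellus as the target; on this read-out higher numbers stand for an effect only at larger amounts of compound and lower numbers for an effect already at smaller amounts.
Compound 2, `O=C(NCCCCc1cccnc1)c1ccc(-c2ccccc2)c(-c2ccccc2)c1`, gives 3.2 mg/kg in this assay.

Of the compounds shown here, two have been measured so far, and compound 1 stands at the lower of the two numbers, meaning it is effective at the smaller dose. Compound 2 needs a clearly larger dose; the gap between the two lies beyond the usual scatter of this kind of measurement.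

Compound 3, `COc1ccc(-c2ccc(C(=O)N[C@H](C)CCCc3cccnc3)cc2[N+](=O)[O-])cc1OC`, has not yet been measured. It keeps the whole core of compound 1 and differs from it in a single place: nitro in place of allyl on an aromatic carbon. Both groups that swap are of the same size in heavy atoms and neither carries a charge; the nitro group brings two hydrogen-bond acceptors where the allyl brought none.

Among the measured compounds shown here, no pair of measured compounds shows what this kind of exchange does here, so the expectation rests only on the closeness of the two structures. The step from compound 1 to compound 3 is expected to be modest, a 1.8-fold higher number from compound 1 to compound 3 (0.26 log units; within the scatter), leaning toward a somewhat larger dose. Compound 3 is therefore expected to give about 0.6 mg/kg in this assay, within a range from 0.2 mg/kg to 2 mg/kg.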

Compound 3, dose for 50% inhibition: 0.19 mg/kg
Compound 3: middle estimate off by 3.2-fold (0.50 log units), on the high side; measured number outside the range, below it.
By their numbers in this assay, from the lowest: compounds 3 and 1 (each within the scatter of the next); then compound 2.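

In this assay, putting nitro in place of allyl on this aromatic carbon gives a 1.7-fold lower number from compound 1 to compound 3 (0.24 log units; within the scatter), so this read-out does not tell the two compounds apart. The position, ortho to a 3,4-dimethoxyphenyl group, thus accepts two very different groups with the same number of heavy atoms and no net charge: allyl, built of carbon only with no hydrogen-bond acceptors, and nitro, built of nitrogen and oxygen and carrying hydrogen-bond acceptors, without any step beyond the usual scatter. Nothing at hand explains why the exchange leaves the dose so little changed.

On these data alone, what remains open is how far this acceptance goes: an amine or a carboxylic acid on the same aromatic carbon, or a longer chain in place of allyl, could give a dose close to those of compound 1 and compound 3 or a clearly different one. A single pair also cannot show whether the same exchange would give a similar step on a different core or in another kind of test.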